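Secondary branched alkylamine in place of the methoxy-bearing amine

This account rests on a few compounds, and the source may have more. Where it says the series, first, only, none or still open, it means among the compounds named here.

Working notes on a small set sharing one core. Compound 1 `CCN(CC)c1nc(C)nc2c1nnn2-c1ccc(C(C)C)cc1Br` carries a diethylamino group on that core, and in an in vitro assay on 293-EBNA cells for binding affinity to corticotropin-releasing factor receptor 1 (Homo sapiens) (a higher number here means a weaker inhibitor, a lower number a stronger inhibitor), compound 1 gives 25.3 nM. Compound 2 `COCC(C)(C)Nc1nc(C)nc2c1nnn2-c1ccc(C(C)C)cc1Br` carries a (1-(methoxymethyl)-1-methylethyl)amino group in the same position, and in this assay compound 2 gives 195 nM. Within the data shown here, the only measured step, a 7.7-fold higher number from compound 1 to compound 2 (0.89 log units; beyond the scatter), places compound 2 at the higher end of the two numbers seen so far, with compound 1 as its only neighbour.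

Compound 3 `CCCCC(CCCC)Nc1nc(C)nc2c1nnn2-c1ccc(C(C)C)cc1Br` is not yet measured. Its change from compound 2 is 1-butylpentyl in place of 1-(methoxymethyl)-1-methylethyl on a nitrogen on an aromatic ring. Among the measured compounds shown here, no measured step covers this exact exchange; the one step known, a 7.7-fold higher number from compound 1 to compound 2 (0.89 log units; beyond the scatter), shows that moving from a plain dialkylamine to the ether-bearing secondary amine raised the number in this assay. Compound 3 returns to a purely hydrocarbon amine, so a move back toward the lower region is expected. For compound 3 in this assay a value of 30 nM is estimated, within 8 nM to 120 nM, which means an expected step of a 6.5-fold lower number from compound 2 to compound 3 (0.81 log units; beyond the scatter).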

Compound 3, inhibition constant: 4.5 nM
The estimate for compound 3 lay 6.7-fold (0.82 log units) above the measured number, outside the stated range (below it).
By their numbers in this assay, from the lowest: compound 3; then compound 1; then compound 2.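

In this assay, the nitrogen on the aromatic carbon of the shared core accepts a much larger hydrocarbon group than either earlier compound carried: 1-butylpentyl in place of 1-(methoxymethyl)-1-methylethyl gives a 43-fold lower number from compound 2 to compound 3 (1.64 log units; beyond the scatter), the largest step in the set. The secondary amine shared by compound 2 and compound 3 therefore does not by itself go with the higher number, and the result also passes the diethylamino group, with a 5.6-fold lower number from compound 1 to compound 3 (0.75 log units; beyond the scatter), so the first step alone gave no hint of how low this position could go. The exchange from compound 2 to compound 3 alters the ether oxygen, the branching and the size of the group together, and no further measurement bears on this result.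

The compounds shown do not separate the ether oxygen from group size; a pair such as 1-ethylpropyl and a methoxy-bearing 1-butylpentyl would do so. As far as these compounds go, how far the number follows chain length also remains open, including whether a shorter 1-propylbutyl or a longer 1-pentylhexyl group keeps it low, and whether a hydroxyl at the end of a butyl chain is accepted.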